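The source may hold more compounds than are shown below. What is called first, only, known or untested is meant among the compounds shown, and "the series" means these compounds.

Among the measured compounds shown here, in a physicochemical assay for solubility, with a stated time of 3 days, at pH 2 (on this read-out lower numbers stand for lower solubility and higher numbers for higher solubility), compound 1 (`NC(=O)c1ccc2[nH]c(-c3ccc(OCCCO)cc3)nc2c1`) gives 185000 nM as the only number available in this small series. Compound 2 (`CC(=O)N1CCC(COc2ccc(-c3nc4cc(C(N)=O)ccc4[nH]3)cc2)CC1`) shares the core of compound 1 but has no place on that scale: the entry for compound 2 reads "not determined" (no result reported) and so it offers no starting value. Compound 3 (`CC(=O)N1CCC(CCOc2ccc(-c3nc4cc(C(N)=O)ccc4[nH]3)cc2)CC1`) follows from compound 2 through one structural change ((1-acetylpiperidin-4-yl)methyl in place of 1-acetylpiperidin-4-yl on a saturated chain carbon bound to an oxygen on an aromatic ring), with (1-acetylpiperidin-4-yl)methyl in place of 1-acetylpiperidin-4-yl on a saturated chain carbon bound to an oxygen on an aromatic ring. For the measured compounds named here, no measured step shows what such a change does. For the step in this assay from compound 2 to compound 3, no shift beyond the scatter is expected, though the missing value for compound 2 means this cannot be checked. The estimate must therefore lean on compound 1 at 185000 nM as its sole anchor, and this compound carries a different group on the oxygen, so the range is kept wide. Compound 3 is estimated in this assay at 80000 nM with an expected range from 15000 nM to 250000 nM around that figure.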

Compound 3, solubility: 87000 nM
For compound 3 the middle estimate is 1.1-fold (0.04 log units) below the measured one; measured number inside the range.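

In this assay, the series now has its first readable step: a 2.1-fold lower number from compound 1 to compound 3 (0.33 log units; beyond the scatter), with 1-acetylpiperidin-4-yl in place of hydroxymethyl on a saturated chain carbon, two bonds along the chain from an oxygen on an aromatic ring, and this modest shift lies beyond the scatter. The step between compound 2 and compound 3 cannot be read, so the series gives no size for (1-acetylpiperidin-4-yl)methyl in place of 1-acetylpiperidin-4-yl. No measurement at hand accounts for the lower number seen with compound 3.

The compounds shown leave open whether the step belongs to the piperidine ring, to the acetyl on its nitrogen, or to the two together, and a free secondary amine in the ring would begin to separate these. They also leave open what a carboxylic acid or a simple morpholine in the same place would give in this assay, and whether a longer chain would move the number further.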